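The compounds below may be only part of what the source reports. "The series", "measured", "known", "first", "only" and "open" are said of these compounds alone.

Compound 2 `CCNC(=O)c1cc(Oc2ccc(NC(=O)c3cc4cccnc4n(-c4ccc(OC)cc4)c3=O)cc2)ccn1` gives 2010 nM in a functional assay on A549 cells (Homo sapiens) for antiproliferative activity, read by MTT assay, with a stated time of 72 h (on this read-out higher numbers stand for weaker inhibition and lower numbers for stronger inhibition), the higher of the two numbers seen so far, while compound 1 `CCNC(=O)c1cc(Oc2ccc(NC(=O)c3cc4cccnc4n(-c4ccc(Cl)cc4)c3=O)cc2)ccn1` gives 250 nM in this assay. Within the data shown here, the one measured step that bears here runs the other way: an 8.0-fold higher number from compound 1 to compound 2 (0.91 log units; beyond the scatter), so replacing the chloro with a methoxy weakened the inhibition. Compound 3 `CCNC(=O)c1cc(Oc2ccc(NC(=O)c3cc4cccnc4n(-c4ccc(F)c(Cl)c4)c3=O)cc2)ccn1` carries 3-chloro-4-fluorophenyl in place of 4-methoxyphenyl on an aromatic nitrogen; this removes the methoxy and brings back a chloro, now together with a fluoro. Among the measured compounds shown here, the new group therefore resembles the one in compound 1 more than the one in compound 2. Because compound 1 stands at 250 nM, the step to compound 3 is expected to reverse most of the loss: a 6.7-fold lower number from compound 2 to compound 3 (0.83 log units; beyond the scatter). For compound 3 in this assay the estimate is 300 nM, with a likely range from 100 nM to 900 nM.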

Compound 3, half-maximal inhibitory concentration: 1920 nM
The estimate for compound 3 lay 6.4-fold (0.81 log units) below the measured number, and the stated range ends below it.
By their numbers in this assay, from the lowest: compound 1; then compounds 3 and 2 (each within the scatter of the next).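

In this assay, putting 3-chloro-4-fluorophenyl in place of 4-methoxyphenyl on the ring nitrogen gives a 1.0-fold lower number from compound 2 to compound 3 (0.02 log units; within the scatter), so carrying a chloro does not by itself restore the low number seen with the 4-chlorophenyl group. Putting the same group in place of 4-chlorophenyl gives a 7.7-fold higher number from compound 1 to compound 3 (0.89 log units; beyond the scatter), which shows that two chloro-bearing rings at this position can differ clearly in this read-out, and that among these three compounds only compound 1 sits apart. Nothing measured here explains this difference.

On these data alone, it remains open whether the higher number of compound 3 goes with the fluoro or with where the chloro sits, and a 4-fluorophenyl or 3-chlorophenyl group would help separate the two. As far as these compounds go, the result for a plain phenyl ring at this position also remains open.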